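A few compounds are considered here, and "the series" means these few. Any claim that something is new, unique, unknown or untested is made for them only; others in the source may bear on it.

Measured so far:
compound 1 `CNC(=O)c1cc(C(=O)NCCC2CCOCC2)cn(Cc2ccccc2)c1=O` — in a physicochemical assay for solubility (on this read-out lower numbers stand for lower solubility and higher numbers for higher solubility), compound 1 gives >= 127 ug/mL
compound 2 `CNC(=O)c1cc(C(=O)NC2CC2)cn(Cc2nccc3[nH]ccc23)c1=O` — in this assay compound 2 gives 73 ug/mL

The entry for compound 1 is a limit of the assay and not a number. From the compounds shown here alone, compound 1 is known only through (the limit of >= 127 ug/mL in this assay, at which 1 of the 2 values shown sits), so where it stands among the measured numbers remains open. Compound 3 `CNC(=O)c1cc(C(=O)NC2CCC2)cn(Cc2ccccc2)c1=O` has not yet been measured in this assay; it differs from compound 1 by cyclobutyl in place of 2-(oxan-4-yl)ethyl on an amide-type nitrogen. Among the measured compounds shown here, no step between measured compounds is available to size this change. A modest downward step is expected, an at least 1.8-fold lower number from compound 1 to compound 3 (0.25 log units; that floor lies within the scatter), not clearly beyond the usual scatter. Compound 3 is estimated at 70 ug/mL, within a range from 25 ug/mL to 160 ug/mL.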

Compound 3, solubility: 28 ug/mL
Compound 3: middle estimate off by 2.5-fold (0.40 log units), on the high side; low and high end bracket the measured number.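

In this assay, placing cyclobutyl in place of 2-(oxan-4-yl)ethyl on an amide-type nitrogen gives an at least 4.5-fold lower number from compound 1 to compound 3 (0.65 log units; beyond the scatter). Among the compounds shown here, this is the first step at this position, and it shows that this one change, with the rest of the core of compound 1 unchanged, moves the read-out beyond the scatter. Compound 1 is known only through a limit of the assay and not a number, so the true size of the step stays unknown: the limit of >= 127 ug/mL in this assay, at which 1 of the 3 values shown sits.

This single change alters the ring, the ring oxygen and the chain together, so their shares cannot be separated. From the compounds shown here alone, how 2-cyclohexylethyl or oxan-4-yl on the same amide-type nitrogen would read remains open.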